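The compounds below may be only part of what the source reports. "The series", "measured", "known", "first", "only" and "open" are said of these compounds alone.

Compound 1 `O=C(CCc1cccc2c1B(O)OC2)Nc1ccc(Cl)cc1`: 5000 nM
Compound 2 `O=C(CCc1cccc2c1B(O)OC2)Nc1cccc(-c2cccc(Cl)c2)c1`: 300 nM
Compound 3 `O=C(CCc1cccc2c1B(O)OC2)Nc1cccc(-c2cccc(OC(F)(F)F)c2)c1`: 460 nM

In a functional assay on SK-OV-3 cells (Homo sapiens) for antiproliferative activity, read by MTT assay, with a stated time of 72 h (on this read-out higher numbers stand for weaker inhibition and lower numbers for stronger inhibition), compound 2 has the lowest of the three numbers; its nearest neighbour is compound 3, with a 1.5-fold higher number from compound 2 to compound 3 (0.19 log units; within the scatter), while compound 1 lies far above it, beyond the scatter. Compound 4 `N#Cc1ccc(-c2cccc(NC(=O)CCc3cccc4c3B(O)OC4)c2)cc1` differs from compound 2 by 4-cyanophenyl in place of 3-chlorophenyl on an aromatic carbon. Within the data shown here, the one measured step that bears on this, the swap of the substituent on the distal ring, was within the scatter; compound 1 shows only that losing the second ring altogether raises the number sharply. Since compound 4 keeps that second ring, the expected step is a 1.5-fold higher number from compound 2 to compound 4 (0.18 log units; within the scatter). Compound 4 is therefore estimated at 450 nM, within 200 nM to 1100 nM.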

Compound 4, half-maximal inhibitory concentration: 340 nM
Compound 4: the middle estimate sits 1.3-fold (0.12 log units) above what was measured; low and high end bracket the measured number.
By their numbers in this assay, from the lowest: compounds 2, 4 and 3 (each within the scatter of the next); then compound 1.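

In this assay, among these compounds, putting 4-cyanophenyl in place of 3-chlorophenyl gives a 1.1-fold higher number from compound 2 to compound 4 (0.05 log units; within the scatter) and so shows that this position accepts more than the one exchange seen earlier, where only the substituent changed from chloro to trifluoromethoxy. Here the substituent is a nitrile, which brings a triple bond and a hydrogen-bond acceptor, and its ring carries it at a different place. No supporting measurement bears on this result. Still open, going by these compounds, is whether an amine or a carboxylic acid on this ring would read within the same scatter.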